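The source may hold more compounds than are shown below. What is called first, only, known or untested is meant among the compounds shown, and "the series" means these compounds.

Compound 3, whose structure is `O=C(Nc1ccc([N+](=O)[O-])cc1)c1ccc(/N=N\c2c[nH]c3ccccc23)cc1`, is the reference point for this piece. In a functional assay on P388 cells (Mus musculus) for inhibition, read by MTT assay, with a stated time of 72 h (on this read-out higher numbers stand for weaker inhibition and lower numbers for stronger inhibition), compound 3 gives 11200 nM, the lowest of the two numbers that have been obtained so far. Within the data shown here, its nearest neighbour among the measured compounds is compound 2, with structure `O=C(Nc1cccc(Cl)c1)c1ccc(/N=N\c2c[nH]c3ccccc23)cc1`, which in this assay gives 267000 nM; the one measured step, a 24-fold lower number from compound 2 to compound 3 (1.38 log units; beyond the scatter), is the only guide available. Compound 1, with structure `O=C(Nc1ccccc1Cl)c1ccc(/N=N\c2c[nH]c3ccccc23)cc1`, is reported in this assay as "not active" (no number reported), with no number given.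

Compound 4, with structure `O=C(Nc1ccc(Cl)cc1)c1ccc(/N=N\c2c[nH]c3ccccc23)cc1`, differs from compound 3 by chloro in place of nitro on an aromatic carbon. Among the measured compounds shown here, no measured step tests this exact change. The step from compound 2 to compound 3 changes both the group and where it sits, so it bears on the present change only loosely; it does, however, show that the two chloro-bearing compounds, compound 1 and compound 2, sit far toward the weak end, and compound 3 alone stands low. The present change returns to a chloro group, so he expects the number for compound 4 to move back upward, in the direction of compound 2, by a step of the order of an 8.9-fold higher number from compound 3 to compound 4 (0.95 log units; beyond the scatter). His estimate for compound 4 in this assay is therefore 100000 nM, with a range from 20000 nM to 400000 nM, and a real chance that only a limit is reported.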

Compound 4, half-maximal inhibitory concentration: 80000 nM
The estimate for compound 4 lay 1.3-fold (0.10 log units) above the measured number; measured number inside the range.
By their numbers in this assay, from the lowest: compound 3; then compound 4; then compound 2.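

Compound 4 keeps the substituent at the same place, para to a large group, so the nitro-to-chloro change is seen here without the shift of position that the earlier step also carried: in this assay it gives a 7.1-fold higher number from compound 3 to compound 4 (0.85 log units; beyond the scatter), a step beyond the scatter. The second step, a 3.3-fold lower number from compound 2 to compound 4 (0.52 log units; beyond the scatter), shows that where the chloro group sits also matters in this series, since the group stays the same and the number still moves beyond the scatter, although this step is smaller than the one for replacing the nitro group. No measured evidence on these compounds accounts for either step.

With only nitro and chloro compared at this place, the compounds shown leave open where an amine, a carboxylic acid or a methoxy group would fall relative to compound 3 and compound 4. Compound 1, the remaining chloro-bearing compound, has no number, so its steps to the others cannot be read and the full effect of moving the chloro group around the ring stays unsettled.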